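A few compounds are considered here, and "the series" means these few. Any claim that something is new, unique, unknown or untested is made for them only; others in the source may bear on it.

Compound 1 `c1ccc(-c2ccc3c(NCCCNCc4ccco4)ccnc3c2)cc1`: 9.47
Compound 2 `COc1cccc(Oc2ccc3c(NCCCNCc4ccco4)ccnc3c2)c1`: 9.28

Among the compounds with values here, in a physicochemical assay for acid dissociation, compound 2 gives 9.28, which lies within the scatter of compound 1 at 9.47, the only other number measured here. Compound 3 `c1coc(CNCCCNc2ccnc3cc(C4CCCCC4)ccc23)c1` differs from compound 2 by cyclohexyl in place of 3-methoxyphenoxy on an aromatic carbon. Within the data shown here, the one measured step that bears on this position is a number 0.19 log units lower from compound 1 to compound 2 (within the scatter), an exchange of the group on the same aromatic carbon that did not move the number beyond the scatter. Compound 3 is therefore expected to stay close to compound 2, with an expected step of a number 0.12 log units higher from compound 2 to compound 3 (within the scatter), not beyond the scatter. The estimate for compound 3 is 9.4, in the range 9.1 to 9.7.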

Compound 3, acid dissociation constant: 9.47
Compound 3: middle estimate off by 0.07 log units, on the low side; measured number inside the range.
By their numbers in this assay, from the lowest: compounds 2, 1 and 3 (each within the scatter of the next).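

In this assay the exchange to cyclohexyl gives a number 0.19 log units higher from compound 2 to compound 3 (within the scatter) and also no change at the digits printed from compound 1 to compound 3 (within the scatter) so a non-aromatic ring of carbon only can stand in place of either aromatic group on this aromatic carbon without the number leaving the scatter. Across compound 1, compound 2 and compound 3, the number therefore stays within the scatter whether the group has an aromatic or a non-aromatic ring and whether or not it has hydrogen-bond acceptors. Nothing available explains this result.

As far as these compounds go, whether an amine or a carboxylic acid on this aromatic carbon would move the number beyond the scatter remains open.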